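The source may report more compounds than this note shows. Statements on the series, on what has been measured and on what is new or still open speak of the compounds shown alone.

In an ADME assay on HaCaT cells (Homo sapiens) for cytotoxicity, read by MTT assay, with a stated time of 72 h (on this read-out higher numbers stand for weaker inhibition and lower numbers for stronger inhibition), compound 2 (`CC(C)(C)C1=CC(=O)C=CC1=O`) gives 95000 nM. Compound 3 (`CNC1=CC(=O)C(C(C)(C)C)=CC1=O`) gives 28000 nM, and compound 1 (`CCCCCCCCNC1=CC(=O)C=C(C(C)(C)C)C1=O`) gives 30000 nM, so these two stand within the scatter of each other and both sit clearly under compound 2. Among the measured compounds shown here, the only measured step, a 3.4-fold lower number from compound 2 to compound 3 (0.53 log units; beyond the scatter), is modest but beyond the scatter, and it introduces methylamino in place of hydrogen on a double-bonded ring carbon.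

Compound 4 (`CCCCCCCCNC1=CC(=O)C(C(C)(C)C)=CC1=O`) follows from compound 3 by placing heptyl in place of hydrogen on a saturated chain carbon bound to an amine nitrogen. For the measured compounds named here, no measured step covers this change directly. The closest evidence is compound 1, which carries the same longer amine chain on a differently arranged core and whose 30000 nM shows no gap from the value of compound 3. No clear shift is therefore expected in this assay. The estimated step, a 1.1-fold lower number from compound 3 to compound 4 (0.03 log units; within the scatter), is expected to stay within the scatter. For compound 4 the estimated value is 26000 nM, with an expected range of 10000 nM to 60000 nM.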

Compound 4, half-maximal inhibitory concentration: > 100000 nM
Compound 4 ended at the assay's limit; the forecaster's own chance of this, stated with the estimate: 5%; middle value at least 3.8-fold (0.58 log units) away from the limit.
By their numbers in this assay, from the lowest: compounds 3 and 1 (each within the scatter of the next); then compound 2. At a limit, above all of these: compound 4.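

Adding heptyl in place of hydrogen on a saturated chain carbon bound to an amine nitrogen gives an at least 3.5-fold higher number from compound 3 to compound 4 (0.55 log units; beyond the scatter) in this assay, so on this read-out the change goes with weaker inhibition. Among the compounds shown here, until now, the only measured step was at a double-bonded ring carbon, so this is the first evidence that a change on the chain itself can move the number beyond the scatter. In this assay, from the compounds shown here alone, compound 4 gives > 100000 nM, which is a limit of the assay and not a number, so the true size of the step stays unknown.

The compounds shown leave open how the number behaves between methylamino and this long chain, which a propyl or butyl chain on the same nitrogen would address. They also leave open whether a hydroxyl group or a carboxylic acid at the end of the long chain would change the outcome.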